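Moving the hydroxy group from compound 2 to compound 3

The source may report more compounds than this note shows. Statements on the series, on what has been measured and on what is new or still open speak of the compounds shown alone.

Compound 1 `O=C(Cc1csc2nc(-c3ccc(Br)cc3)cn12)N/N=C/c1ccccc1`: > 100000 nM
Compound 2 `O=C(Cc1csc2nc(-c3ccc(Br)cc3)cn12)N/N=C/c1ccccc1O`: 25100 nM

In a functional assay on SNB-19 cells (Homo sapiens) for inhibition, read by sulforhodamine B assay, with a stated time of 48 h (on this read-out lower numbers stand for stronger inhibition of growth and higher numbers for weaker inhibition of growth), the reading for compound 1 is a limit, not a number. Among the compounds with values here, compound 2 therefore holds the only true number so far. Compound 3 `O=C(Cc1csc2nc(-c3ccc(Br)cc3)cn12)N/N=C/c1ccc(O)cc1` differs from it by 4-hydroxyphenyl in place of 2-hydroxyphenyl on a carbon with a double bond to nitrogen, with 4-hydroxyphenyl in place of 2-hydroxyphenyl. Within the data shown here, one measured step bears on this: hydroxy in place of hydrogen on an aromatic carbon gave an at least 3.9-fold lower number from compound 1 to compound 2 (0.60 log units; beyond the scatter). Compound 3 keeps a hydroxy group, so no step beyond the scatter is expected, with only a slight lean towards a higher number. The expected step is a 1.4-fold higher number from compound 2 to compound 3 (0.14 log units; within the scatter). For compound 3 the estimated value is 35000 nM, within an expected range of 12000 nM to 100000 nM.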

Compound 3, concentration for total growth inhibition: > 100000 nM
Compound 3 was reported as a limit; the forecaster's own chance of this, stated with the estimate: 30%; middle value at least 2.8-fold (0.45 log units) from the limit.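

In this assay, 4-hydroxyphenyl in place of 2-hydroxyphenyl gave an at least 3.9-fold higher number from compound 2 to compound 3 (0.60 log units; beyond the scatter), so at this position the presence of a hydroxy group is not enough on its own: only 2-hydroxyphenyl has so far given a true number. The step from compound 1 to compound 3 cannot be read, as both readings are limits. Only compound 2 falls under the limit of the assay: the limit of > 100000 nM in this assay, at which 2 of the 3 values shown sit.

Going by these compounds, whether an amine or a methoxy group in place of the hydroxy of 2-hydroxyphenyl would also give a true number remains open.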